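Cyanophenoxy for fluorophenyl: expected shift in clearance

A few compounds are considered here, and "the series" means these few. Any claim that something is new, unique, unknown or untested is made for them only; others in the source may bear on it.

Compound 1 `O=C(Nc1cc(-c2ccccn2)n[nH]1)N1CCC(Oc2ccccc2)CC1`: 27.3 mL.min-1.g-1
Compound 2 `O=C(Nc1cc(-c2ccccn2)n[nH]1)N1CCC(Oc2ccccn2)CC1`: reported only as a limit, < 11.9 mL.min-1.g-1
Compound 3 `O=C(Nc1cc(-c2ccccn2)n[nH]1)N1CCC(c2ccc(F)cc2)CC1`: 42.5 mL.min-1.g-1

In an ADME assay on liver for metabolic stability, with Liver microsome (Homo sapiens) as the target, using microsomes (on this read-out lower numbers stand for slow clearance and higher numbers for fast clearance), compound 3 gives 42.5 mL.min-1.g-1, the higher of the two numbers shown, though its gap to compound 1, a 1.6-fold higher number from compound 1 to compound 3 (0.19 log units; within the scatter), lies within the scatter. Compound 2 is known only by a limit of the assay, < 11.9 mL.min-1.g-1 (the limit of < 11.9 mL.min-1.g-1 in this assay, at which 1 of the 3 values shown sits).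

Compound 4 `N#Cc1ccc(OC2CCN(C(=O)Nc3cc(-c4ccccn4)n[nH]3)CC2)cc1` is not yet measured. It differs from compound 3 in one place: 4-cyanophenoxy in place of 4-fluorophenyl on a saturated ring carbon. For the measured compounds named here, two measured steps bear on this. The step of an at least 3.5-fold higher number from compound 2 to compound 3 (0.55 log units; beyond the scatter) shows that exchanging an oxygen-linked aryl group for 4-fluorophenyl raised the number beyond the scatter, and the step of a 1.6-fold higher number from compound 1 to compound 3 (0.19 log units; within the scatter) points the same way though within the scatter. Compound 4 returns to an oxygen-linked aryl group, now carrying a nitrile, so the reverse direction is expected.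

For compound 4 in this assay a lower number than compound 3 is therefore expected, a step of a 2.4-fold lower number from compound 3 to compound 4 (0.37 log units; beyond the scatter). The estimate for compound 4 is 18 mL.min-1.g-1, with a range from 9 mL.min-1.g-1 to 35 mL.min-1.g-1; it may well fall at or under the limit at which compound 2 sits.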

Compound 4, intrinsic clearance in microsomes: 14.7 mL.min-1.g-1
Beside the measured number, compound 4's estimate is 1.2-fold (0.09 log units) above it, within the range that was stated.
By their numbers in this assay, from the lowest: compounds 4, 1 and 3 (each within the scatter of the next, the first and the last beyond it). At a limit, below all of these: compound 2.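

In this assay, the step of a 2.9-fold lower number from compound 3 to compound 4 (0.46 log units; beyond the scatter) lies beyond the scatter, whereas the step from the unsubstituted phenoxy of compound 1 to the 4-fluorophenyl of compound 3 stayed within it, so 4-cyanophenoxy on this saturated ring carbon separates from 4-fluorophenyl in a way phenoxy did not. Placing a nitrile on the phenoxy ring gives a 1.9-fold lower number from compound 1 to compound 4 (0.27 log units; within the scatter), which is within the scatter, so this read-out cannot tell compound 4 from compound 1. The step of an at least 1.2-fold higher number from compound 2 to compound 4 (0.09 log units; that floor lies within the scatter) rests on a limit and cannot order 4-cyanophenyl against pyridin-2-yl on the oxygen: the limit of < 11.9 mL.min-1.g-1 in this assay, at which 1 of the 4 values shown sits.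

Compound 3 and compound 4 differ in both the linking oxygen and the group on the aromatic ring, and the compounds shown do not separate these two parts, as a 4-fluorophenoxy or a 4-cyanophenyl group on the same ring carbon could. On these data alone, how an amine or a carboxylic acid in place of the nitrile would read in this assay also remains open.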